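The source may report more compounds than this note shows. Statements on the series, on what has been measured and on what is new or still open speak of the compounds shown alone.

The measured compounds:

Compound 1, `COc1cccc(N2C(=O)COc3ccc(-c4cnc(Cl)c(NS(=O)(=O)c5ccc(F)cc5)c4)cc32)c1`, in a functional assay on HCT-116 cells (Homo sapiens) for antiproliferative activity, read by MTT assay, with a stated time of 72 h (on this read-out higher numbers stand for weaker inhibition and lower numbers for stronger inhibition), gives only a limit, > 40000 nM.
Compound 2, `CC(C)N1C(=O)COc2ccc(-c3cnc(Cl)c(NS(=O)(=O)c4ccc(F)cc4)c3)cc21`, in this assay gives 18900 nM.
Compound 3, `COc1cccc(N2C(=O)COc3ccc(-c4cccc(NS(=O)(=O)c5ccc(F)cc5)c4)cc32)c1`, in this assay gives only a limit, > 40000 nM.

For the measured compounds named here, the one structural change shared by two pairs is isopropyl in place of 3-methoxyphenyl on an amide-type nitrogen in a ring, made once between compound 1 and compound 2 and once again between compound 3 and compound 4, whose structure is `CC(C)N1C(=O)COc2ccc(-c3cccc(NS(=O)(=O)c4ccc(F)cc4)c3)cc21`. The place of the change in the second pair is isopropyl in place of 3-methoxyphenyl on an amide-type nitrogen in a ring, the same place word for word, so it is the same kind of change on a different core. The difference between the core of compound 1 and the core of compound 3 is not broken down here.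

In the measured pair the step is an at least 2.1-fold lower number from compound 1 to compound 2 (0.32 log units; beyond the scatter), and its size can only be given as a lower bound because of the limit of > 40000 nM in this assay, at which 2 of the 3 values shown sit. Compound 3 also sits at that limit, so the step to compound 4 starts from a bound and not from a number.

The account expects the same kind of step from compound 3 to compound 4, estimated as an at least 1.3-fold lower number from compound 3 to compound 4 (0.12 log units; that floor lies within the scatter), resting on the measured step of compound 1 to compound 2 of an at least 2.1-fold lower number from compound 1 to compound 2 (0.32 log units; beyond the scatter). For compound 4 in this assay the estimate is 30000 nM, within 12000 nM to 80000 nM, with a real chance that compound 4 again yields only a limit.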

Compound 4, half-maximal inhibitory concentration: 22600 nM
Compound 4: middle estimate off by 1.3-fold (0.12 log units), on the high side, within the range that was stated.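

On the core of compound 3, isopropyl in place of 3-methoxyphenyl on the amide-type nitrogen in a ring gives an at least 1.7-fold lower number from compound 3 to compound 4 (0.24 log units; that floor lies within the scatter) in this assay. The change therefore points the same way on the two cores, with the 3-methoxyphenyl compound giving only a limit and the isopropyl compound a measured number each time, but the sizes of the two steps cannot be set against each other: the same change on two cores in this assay, an at least 2.1-fold lower number (0.32 log units; beyond the scatter) from compound 1 to compound 2 and an at least 1.7-fold lower number (0.24 log units; that floor lies within the scatter) from compound 3 to compound 4; the limit leaves it open whether they differ This carries the direction of the change from one core to the other, but not its true size on either core, because each step starts from a limit and not from a number: the limit of > 40000 nM in this assay, at which 2 of the 4 values shown sit.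

The compounds shown leave open how far the read-out would move if the 3-methoxyphenyl compounds could be given as numbers, and whether the direction of the change would hold on a third core. They also leave open what other groups on the same nitrogen would give in this assay, such as a methyl, a longer chain or a chain ending in an amine or a carboxylic acid.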